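This account rests on a few compounds, and the source may have more. Where it says the series, first, only, none or still open, it means among the compounds named here.

Compound 1 `Nc1nn(C(=O)Nc2ccc(Cc3ccccc3)cc2)c2ccccc12`: 22200 nM
Compound 2 `COc1ccc(NC(=O)Nc2n[nH]c3ccccc23)cc1`: > 100000 nM

Within the data shown here, in a functional assay on RXF 393 cells (Homo sapiens) for inhibition, read by sulforhodamine B assay, with a stated time of 48 h (a lower number here means a stronger inhibitor of growth, a higher number a weaker inhibitor of growth), compound 1 gives 22200 nM, the only plain number among the two values shown. Compound 2 shows only a limit of this assay, > 100000 nM, not a number. This is the limit of > 100000 nM in this assay, at which 1 of the 2 values shown sits. Compound 3 `CCCCOc1ccc(NC(=O)n2nc(N)c3ccccc32)cc1` has not been measured yet. It differs from compound 1 by butoxy in place of benzyl on an aromatic carbon. Among the measured compounds shown here, no measured pair shows an exchange of this kind. For compound 3 the step is expected to be modest, if anything toward weaker growth inhibition, estimated as a 1.4-fold higher number from compound 1 to compound 3 (0.13 log units; within the scatter). Compound 3 is therefore expected to give about 30000 nM, likely between 10000 nM and 100000 nM.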

Compound 3, concentration for 50% growth inhibition: 29600 nM
For compound 3 the middle estimate is 1.0-fold (0.01 log units) above the measured one, and the stated range covers the measured number.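

In this assay butoxy in place of benzyl gives a 1.3-fold higher number from compound 1 to compound 3 (0.12 log units; within the scatter) and so no change that can be told from scatter. This position, para to a large group, therefore holds a chain with no ring as well as it holds a six-membered aromatic ring, and that ring is not needed to keep this level of growth inhibition. Nothing measured here explains why the two groups match. Going by these compounds, whether an amine, a carboxylic acid or a longer chain at this position would move the number stays open.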